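Propyl in Place of Hydrogen on a Fused Core

The compounds below may be only part of what the source reports. "The series", "measured", "known", "first", "only" and "open" are said of these compounds alone.

Compound 1 `CCOC(=O)Cn1ncc2c(C)ncn2c1=O` gives in a functional assay for inhibition, with Homo sapiens as the target (on this read-out lower numbers stand for stronger inhibition and higher numbers for weaker inhibition), a value of > 48000 nM, which is a limit of the assay and not a number.
Compound 2 `CCOC(=O)Cn1ncc2cncn2c1=O` gives in this assay a value of > 48000 nM, again a limit.
Compound 3 `CCCc1nc(C)c2c(C(C)C)nnc(O)n12` gives in this assay a value of > 48000 nM, also a limit.

Compound 1 therefore stands nowhere on a scale: its result is only a limit, and so are the results of its two companions, all sitting at the limit of > 48000 nM in this assay, at which 3 of the 3 values shown sit. The unmeasured compound 4 `CCCc1nc(C)c2cnn(CC(=O)OCC)c(=O)n12` differs from compound 1 in one place: propyl in place of hydrogen on an aromatic carbon.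

Within the data shown here, only one measured step touches compound 1, the step that the two limits leave unreadable from compound 1 to compound 2, and its size cannot be read because both of its ends sit at the limit of > 48000 nM in this assay, at which 3 of the 3 values shown sit. Among the measured compounds shown here, compound 3 shares no single-place step with compound 1, and its value shows only another limit. For the measured compounds named here, no measured step can therefore show whether a small alkyl group on this fused core moves the read-out in this assay at all, let alone by how much.

With three limits and no readable step, the expectation for compound 4 is that the step that the limit leaves unreadable from compound 1 to compound 4 will again not rise above the floor of the assay. The estimated result for compound 4 in this assay is 60000 nM, expected to lie between 20000 nM and 200000 nM, most likely reported once more as a limit.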

Compound 4, half-maximal inhibitory concentration: > 48000 nM
Compound 4 gave a limit, no number (the forecaster's own chance of this, stated with the estimate: 80%); the middle value does not contradict the limit.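

On these data alone, no new step can be read: compound 1 and compound 4 both give only a limit, so the size of the step between them stays unknown: the limit of > 48000 nM in this assay, at which 4 of the 4 values shown sit.

The compounds shown leave open whether any change on the shared core moves the read-out in this assay at all, and what structure would give a number instead of a limit.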